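The compounds below may be only part of what the source reports. "The series", "measured", "known", "first", "only" and "open" are said of these compounds alone.

Working notes on the series. Of the compounds shown here, two have been measured in a functional assay for inhibition of sodium/hydrogen exchanger (Oryctolagus cuniculus); a lower number here means a stronger inhibitor, a higher number a weaker inhibitor. Compound 1 `Cc1cc(Cl)c(S(C)(=O)=O)cc1C(=O)N=C(N)N` gives 25 nM. Compound 2 `COc1cc(C)c(C(=O)N=C(N)N)cc1S(C)(=O)=O` gives 16 nM. The single step between them, a 1.6-fold lower number from compound 1 to compound 2 (0.19 log units; within the scatter), is within the scatter, so compound 2 and compound 1 cannot be ordered on the numbers shown; compound 2 simply sits at the same level as its only neighbour.

Compound 3 `Cc1cc(OC2CCCCC2)c(S(C)(=O)=O)cc1C(=O)N=C(N)N` is not yet measured. It differs from compound 2 by cyclohexyl in place of methyl on an oxygen on an aromatic ring. For the measured compounds named here, no measured step touches the group carried on that oxygen; the only measured step, a 1.6-fold lower number from compound 1 to compound 2 (0.19 log units; within the scatter), concerns the exchange of chloro for methoxy on the aromatic carbon and was itself within the scatter. Going by the values given here, the step from compound 2 to compound 3 therefore has no direct precedent here, and nothing in the data points to a change in this assay in either direction beyond the scatter. On that basis the step of a 1.3-fold higher number from compound 2 to compound 3 (0.10 log units; within the scatter) is expected to be flat, with a wide allowance for the unprecedented change. Compound 3 is thus estimated at 20 nM in this assay, within a range of 5 nM to 80 nM.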

Compound 3, half-maximal inhibitory concentration: 37 nM
Beside the measured number, compound 3's estimate is 1.9-fold (0.27 log units) below it, within the range that was stated.
By their numbers in this assay, from the lowest: compounds 2, 1 and 3 (each within the scatter of the next, the first and the last beyond it).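

In this assay the group carried on the oxygen now has its first measured change, and cyclohexyl in place of methyl gives a 2.3-fold higher number from compound 2 to compound 3 (0.36 log units; beyond the scatter), a modest step that lies beyond the scatter, so the number at this position does respond to that group, though only slightly for an exchange of a single carbon for a six-membered ring of carbon only. Set against chloro on the same aromatic carbon, cyclohexyloxy gives a 1.5-fold higher number from compound 1 to compound 3 (0.17 log units; within the scatter), which is within the scatter, so compound 3 and compound 1 sit at one level and this position holds cyclohexyloxy, methoxy and chloro within a narrow span of numbers. No measurement bearing on the reason for the step from methoxy to cyclohexyloxy is available.

As far as these compounds go, with only methyl and cyclohexyl compared on that oxygen, it remains open whether the step follows the number of carbons in the group or the presence of the ring. An ethyl group, a longer open chain or a phenyl ring on the same oxygen would separate those readings, and an amine or a carboxylic acid at the end of such a chain would test whether the position tolerates more than carbon alone.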